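The source may hold more compounds than are shown below. What is called first, only, known or untested is meant among the compounds shown, and "the series" means these compounds.

Three compounds have been measured in an ADME assay on Vero cells (Chlorocebus sabaeus) for cytotoxicity, with a stated time of 7 days; a higher number here means that more compound is tolerated, a lower number that less compound is tolerated:

Compound 1, `COc1cccc(CN2C(=O)CN(C(=O)c3cc4cc(OC)ccc4o3)C[C@@H]2CCc2ccccc2)c1`, gives 4500 nM.
Compound 2, `COc1ccc2[nH]c(C(=O)N3CC(=O)N(Cc4ccccc4)[C@@H](CN4CCCCC4)C3)cc2c1`, gives 76900 nM.
Compound 3, `COc1ccc2[nH]c(C(=O)N3CC(=O)N(Cc4ccoc4)[C@@H](Cc4ccccc4)C3)cc2c1`, reaches only the limit of the assay, > 10000 nM.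

Of the two compounds with a real number, compound 2 stands highest: the nearest number, that of compound 1, is lower by a wide margin, well beyond the scatter of repeated measurements. The third value is a limit and not a number, so it cannot be ranked against the others.

Compound 4, `COc1ccc2[nH]c(C(=O)N3CC(=O)N(Cc4ccccc4)[C@@H](CN4CCN(c5ccccn5)CC4)C3)cc2c1`, is compound 2 with one part exchanged: 4-(pyridin-2-yl)piperazin-1-yl in place of piperidin-1-yl on a saturated chain carbon bound to a saturated ring carbon. Among the measured compounds shown here, no pair of measured compounds differs in just one place, so there is no measured step here to lean on, and the effect of this exchange has to be guessed from the structures alone. A larger and more acceptor-rich group replaces a small saturated ring. The step is expected to be a 1.9-fold lower number from compound 2 to compound 4 (0.28 log units; within the scatter), a change of modest size leaning toward less tolerated compound. Compound 4 is therefore estimated at 40000 nM in this assay, with a range from 10000 nM to 100000 nM.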

Compound 4, half-maximal cytotoxic concentration: > 30000 nM
Compound 4 was reported as a limit; the forecaster's own chance of this, stated with the estimate: 20%; the middle value does not contradict the limit.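

In this assay compound 4 gives > 30000 nM, which is a limit of the assay and not a number, so no size can be read for the step between compound 2 and compound 4. The compounds shown leave open how far, and in which direction, 4-(pyridin-2-yl)piperazin-1-yl in place of piperidin-1-yl moves the number.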